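The source may hold more compounds than are shown below. What is called first, only, known or untested is meant among the compounds shown, and "the series" means these compounds.

Of the compounds shown here, two built on a shared core have been measured. Compound 1 `C=C(Br)C(=O)Nc1cccc(-c2cn3nc(Cc4cccc(OC)c4)sc3n2)c1` carries a 3-methoxybenzyl group; in a functional assay on FM3A cells (Mus musculus) for inhibition, read by cell counting, with a stated time of 2 days (a lower number here means a stronger inhibitor, a higher number a weaker inhibitor), compound 1 gives 1100 nM. Compound 2 `C=C(Br)C(=O)Nc1cccc(-c2cn3nc(-c4cccc(OC)c4)sc3n2)c1` carries a 3-methoxyphenyl group in its place, and in this assay compound 2 gives 500 nM. Going by the values given here, the swap produced a 2.2-fold lower number from compound 1 to compound 2 (0.34 log units; beyond the scatter), which leaves compound 2 with the lowest of the two numbers so far.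

Compound 3 `C=C(Br)C(=O)Nc1cccc(-c2cn3nc(-c4ccc(OC)c(OC)c4)sc3n2)c1` has not yet been measured. It differs from compound 2 by methoxy in place of hydrogen on an aromatic carbon. Among the compounds with values here, the only measured step exchanged the linker between the core and the methoxy-bearing ring; no measured step adds a group to that ring, so nothing measured bears directly on this change. Lacking such a guide, the expected step of no change at the digits printed from compound 2 to compound 3 (within the scatter) is none beyond the scatter. Compound 3 is therefore estimated at 500 nM, within a range from 200 nM to 1300 nM.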

Compound 3, half-maximal inhibitory concentration: 110 nM
Estimate against measurement, compound 3: 4.5-fold (0.66 log units) above; measured number below the stated range.
By their numbers in this assay, from the lowest: compound 3; then compound 2; then compound 1.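

Going by these compounds alone, this is the first measured change on the methoxy-bearing ring itself rather than on the link between that ring and the core, and in this assay it gives a 4.5-fold lower number from compound 2 to compound 3 (0.66 log units; beyond the scatter). So this ring accepts a second methoxy group, ortho to the first and para to a large group, and the number falls further. Taken together with the change from 3-methoxybenzyl, the replacement by 3,4-dimethoxyphenyl gives a 10-fold lower number from compound 1 to compound 3 (1.00 log units; beyond the scatter); nothing available explains why the added methoxy has this effect.

Going by these compounds, it remains open whether methoxy itself matters at this carbon, or whether a hydroxyl, a fluorine or an ethoxy group would give a similar number. Also open, on these data alone, is whether a third methoxy group on the same ring would lower the number any further.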